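Ethyl Added at the Phenoxy Ring of a Benzamide Series

A few compounds are considered here, and "the series" means these few. Any claim that something is new, unique, unknown or untested is made for them only; others in the source may bear on it.

Compound 1 `Nc1ccccc1NC(=O)c1ccc(COc2ccccc2)cc1`: 5670 nM
Compound 2 `O=C(NO)c1ccc(COc2ccccc2)cc1`: "not determined" (no result reported)
Compound 3 `Nc1ccccc1NC(=O)c1ccc(CN2CCc3cc(Br)ccc32)cc1`: 7390 nM

Three compounds have been studied in a functional assay on MGC-803 cells (Homo sapiens) for antiproliferative activity, read by CCK-8 assay, with a stated time of 72 h; on this read-out higher numbers stand for weaker inhibition and lower numbers for stronger inhibition. Compound 1 gives 5670 nM in this assay, and compound 3 gives 7390 nM. These two numbers lie within the usual scatter of each other, so no distinction between compound 1 and compound 3 can be drawn from them. Compound 2, the hydroxamic acid of the same core, has no result in this assay. For the measured compounds named here, compound 1 thus carries one of only two numbers, and neither stands apart from the other.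

Compound 4 `CCc1ccc(OCc2ccc(C(=O)Nc3ccccc3N)cc2)cc1` is yet to be measured. It differs from compound 1 in one place: ethyl in place of hydrogen on an aromatic carbon. Going by the values given here, no step between two measured compounds shows what such a change does on this series, so the expectation rests on compound 1 alone.

An ethyl group entering at this position is expected to move the number only modestly, if at all; the step of a 1.3-fold lower number from compound 1 to compound 4 (0.10 log units; within the scatter) is estimated to fall within or near the scatter. Compound 4 is therefore expected to give about 4500 nM in this assay, within a range from 1500 nM to 14000 nM.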

Compound 4, half-maximal inhibitory concentration: 5880 nM
Estimate against measurement, compound 4: 1.3-fold (0.12 log units) below; measured number inside the range.
By their numbers in this assay, from the lowest: compounds 1, 4 and 3 (each within the scatter of the next).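

The change from phenyl to 4-ethylphenyl gives this series its first step between two measured compounds. In this assay that step reads as a 1.0-fold higher number from compound 1 to compound 4 (0.02 log units; within the scatter) and so does not separate the two compounds. For the compounds shown here, on this aromatic carbon, para to a large group, an ethyl group with its 2 heavy atoms of carbon therefore leaves the number indistinguishable from that of the unsubstituted phenyl, which the earlier compounds could not show, since none of them formed a step of this kind. Nothing available here bears on why the result comes out this way.

Going by these compounds alone, whether an amine, a carboxylic acid or a longer chain at this place would read the same as ethyl remains open, and with only one step at one position, no trend can be drawn for the group that sits there. Also open, going by these compounds, is how ethyl would read at another carbon of the same ring, and whether the hydroxamic acid of compound 2, which has no number in this assay, would give any reading to compare with the benzamides.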